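Indole swap in a hydroxamate series still sitting at the limit

The compounds below may be only part of what the source reports. "The series", "measured", "known", "first", "only" and "open" are said of these compounds alone.

Compound 1 `O=C(COc1ccc(CN2CC=C(c3c[nH]c4ccc(F)cc34)CC2)c(F)c1)NO`: in a functional assay on HCT-116 cells (Homo sapiens) for antiproliferative activity, with a stated time of 72 h (a lower number here means a stronger inhibitor, a higher number a weaker inhibitor), compound 1 gives > 5000 nM, which is a limit of the assay and not a number.
Compound 2 `Cc1[nH]c2ccccc2c1C1=CCN(C(=O)c2ccc(OCC(=O)NO)cc2)CC1`: in this assay compound 2 gives > 5000 nM, again a limit.
Compound 3 `O=C(COc1ccc(C(=O)N2CC=C(c3c[nH]c4ccc(F)cc34)CC2)cc1)NO`: in this assay compound 3 gives > 5000 nM, also a limit.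

All three measured values share one feature: the limit of > 5000 nM in this assay, at which 3 of the 3 values shown sit. Compound 3 and compound 2 differ in a single place, (2-methyl-1H-indol-3-yl in place of 5-fluoro-1H-indol-3-yl on a double-bonded ring carbon), and the resulting step is a step that the two limits leave unreadable from compound 3 to compound 2. The unmeasured compound 4 `Cc1[nH]c2ccccc2c1C1=CCN(Cc2ccc(OCC(=O)NO)cc2F)CC1` carries the same change relative to compound 1, (2-methyl-1H-indol-3-yl in place of 5-fluoro-1H-indol-3-yl on a double-bonded ring carbon); the surroundings of the change are described in identical words for both pairs, so it is the same change, occurring twice among these compounds. How the core of compound 1 differs from the core of compound 3 is not broken down here.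

The step from compound 1 to compound 4 is expected to be a step that the limit leaves unreadable from compound 1 to compound 4, an expectation resting on the unreadable a step that the two limits leave unreadable from compound 3 to compound 2. Compound 4 is accordingly expected to give 9000 nM, within 3000 nM to 30000 nM, and most probably to be reported only as a limit.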

Compound 4, half-maximal inhibitory concentration: 1220 nM
Compound 4: middle estimate off by 7.4-fold (0.87 log units), on the high side; the measured number lies below the stated range.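

In this assay, putting 2-methyl-1H-indol-3-yl in place of 5-fluoro-1H-indol-3-yl on the core of compound 1 gives an at least 4.0-fold lower number from compound 1 to compound 4 (0.61 log units; beyond the scatter), so on this core the change brings a gain beyond the scatter. The same change on the other core, from compound 3 to compound 2, cannot be read, because both of its ends sit at the limit: the limit of > 5000 nM in this assay, at which 3 of the 4 values shown sit. The change is therefore read on one core only, and nothing here shows either that its gain carries over to the core of compound 3 or that it fails to.

The compounds shown leave open whether the plain 1H-indol-3-yl or 5-fluoro-2-methyl-1H-indol-3-yl would separate the part played by the added methyl from that of the lost fluorine. Also open, on these data alone, is how compound 4 would respond to a change elsewhere, such as a carboxylic acid in place of the hydroxamate or a longer chain leading to it.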